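The source may hold more compounds than are shown below. What is called first, only, known or untested is meant among the compounds shown, and "the series" means these compounds.

In a functional assay on HeLa cells (Homo sapiens) for antiproliferative activity, read by spectrophotometry, with a stated time of 2 days (a lower number here means a stronger inhibitor of growth, a higher number a weaker inhibitor of growth), compound 1 `COc1cc(Nc2ncc(C(F)(F)F)c(N3Cc4cccc(N(C)S(C)(=O)=O)c4C3)n2)c(OC)cc1Cl` gives 16500 nM. Compound 2 `CN(c1cccc2c1CN(c1nc(Nc3ccc(C(F)(F)F)cc3)ncc1C(F)(F)F)C2)S(C)(=O)=O` gives > 30000 nM, and this is a limit of the assay, not a number. Compound 2 therefore has no exact position, and any comparison with it can only be loose.

Compound 3 `Cc1cc(Cl)ccc1Nc1ncc(C(F)(F)F)c(N2Cc3cccc(N(C)S(C)(=O)=O)c3C2)n1` has the same core, but carries 4-chloro-2-methylphenyl in place of 4-(trifluoromethyl)phenyl on a nitrogen on an aromatic ring. Going by the values given here, only one measured step bears on this change, an at least 1.8-fold higher number from compound 1 to compound 2 (0.25 log units; that floor lies within the scatter). It replaced 4-chloro-2,5-dimethoxyphenyl with 4-(trifluoromethyl)phenyl at the same place, so it shows little about how far this position can move the number. Among the compounds with values here, the group entering compound 3 is closer in name to the one in compound 1, which has a value of 16500 nM, so a number near that one seems a reasonable expectation. The expected step of an at least 1.5-fold lower number from compound 2 to compound 3 (0.17 log units; that floor lies within the scatter) is small, slightly toward stronger growth inhibition, and may not exceed the scatter. For compound 3 the estimated value is 20000 nM, with an expected range from 8000 nM to 30000 nM.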

Compound 3, concentration for 50% growth inhibition: 17400 nM
The estimate for compound 3 lay 1.1-fold (0.06 log units) above the measured number; low and high end bracket the measured number.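

In this assay, putting 4-chloro-2-methylphenyl in place of 4-chloro-2,5-dimethoxyphenyl on the nitrogen gives a 1.1-fold higher number from compound 1 to compound 3 (0.02 log units; within the scatter), so the two methoxy groups of compound 1 can give way to a single methyl with no readable change in growth inhibition. Putting the same group in place of 4-(trifluoromethyl)phenyl gives an at least 1.7-fold lower number from compound 2 to compound 3 (0.23 log units; that floor lies within the scatter), a first hint that this position might respond to the choice of ring substituents, although that floor lies within the scatter and shows no firm difference. Compound 2 has only a limit and not a number, so the true size of that step stays unknown: the limit of > 30000 nM in this assay, at which 1 of the 3 values shown sits.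

The compounds shown leave open whether any group at this position can bring the number far below those of compound 1 and compound 3, as all three groups here are substituted phenyl rings. A phenyl ring carrying an amine or a carboxylic acid, or a simple alkyl chain on this nitrogen in place of the ring, would test how far the position can move the number in this assay.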